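A few compounds are considered here, and "the series" means these few. Any claim that something is new, unique, unknown or untested is made for them only; others in the source may bear on it.

In a functional assay on Raji cells (Homo sapiens) for antiproliferative activity, read by CCK-8 assay, with a stated time of 48 h (a higher number here means a weaker inhibitor, a lower number a stronger inhibitor), compound 1 (`C=CC(=O)Nc1cccc(Nc2nc(Nc3ccc(OCC(=O)N(CCOC)CCOC)cc3)ncc2Cl)c1`) gives 20100 nM, compound 2 (`C=CC(=O)Nc1cccc(Nc2nc(Nc3ccc(OCC(=O)N(CCOC)CCOC)c(Cl)c3)ncc2Cl)c1`) gives 19300 nM and compound 3 (`C=CC(=O)Nc1cccc(Nc2nc(Nc3ccc(OCC4CCCO4)cc3)ncc2Cl)c1`) gives 19100 nM. These values lie within the scatter of one another, so compound 3 stands level with compound 1 and compound 2, and no order can be read among them. Compound 4 (`C=CC(=O)Nc1cccc(Nc2nc(Nc3ccc(OCC4CCCO4)cc3)ncc2F)c1`) has fluoro in place of chloro on an aromatic carbon of a six-membered aromatic ring with 2 nitrogen, ortho to a large group, two atoms from the ring nitrogen and para to a large group: fluoro in place of chloro on an aromatic carbon. Neither measured step alters this carbon, so both bear on it only indirectly. Chloro in place of hydrogen on an aromatic carbon gives a 1.0-fold lower number from compound 1 to compound 2 (0.02 log units; within the scatter), and oxolan-2-yl in place of bis(2-methoxyethyl)carbamoyl gives a 1.1-fold lower number from compound 1 to compound 3 (0.02 log units; within the scatter). Within the data shown here, no measured compound carries fluoro, so this exchange itself is untested. The expected step in this assay is a 1.2-fold lower number from compound 3 to compound 4 (0.08 log units; within the scatter), with no change expected beyond the scatter. For compound 4 the estimated value is 16000 nM, with an expected range from 7000 nM to 35000 nM.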

Compound 4, half-maximal inhibitory concentration: 38600 nM
Estimate against measurement, compound 4: 2.4-fold (0.38 log units) below; measured number outside the range, above it.
By their numbers in this assay, from the lowest: compounds 3, 2, 1 and 4 (each within the scatter of the next, the first and the last beyond it).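

In this assay, fluoro in place of chloro on this aromatic carbon gives a 2.0-fold higher number from compound 3 to compound 4 (0.31 log units; beyond the scatter), the only step in the series shown that lies beyond the scatter, though a modest one. This position therefore responds to a single-atom exchange, whereas neither chloro in place of hydrogen on the other ring nor the change in the chain on oxygen moved the number beyond the scatter. The two groups count alike under the structural comparison, with one heavy atom each, no hydrogen-bond donors or acceptors and no net charge, and nothing shown gives a reason for the step.

Open, from the compounds shown here alone, is how hydrogen, bromo, methyl or nitrile would read on this carbon. Also open, going by these compounds, is whether the same exchange holds with the bis(2-methoxyethyl)carbamoyl chain of compound 1.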